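From ethoxy to acetoxy: a small step expected

A few compounds are considered here, and "the series" means these few. Any claim that something is new, unique, unknown or untested is made for them only; others in the source may bear on it.

Compound 1 `CCOc1ccc2c(c1)C(C)=CC(C)(C)N2Cc1ccccc1` gives 97000 nM in an ADME assay on L6 cells (Rattus norvegicus) for cytotoxicity, read by resazurin assay, with a stated time of 70 h (a lower number here means a stronger inhibitor, a higher number a weaker inhibitor), and stands level with compound 2 `CCOc1ccc2c(c1)C(C)=CC(C)(C)N2Cc1ccc(F)c(F)c1` at 90000 nM on these numbers. Among the compounds with values here, the one measured step of a 1.1-fold lower number from compound 1 to compound 2 (0.03 log units; within the scatter) lies within the scatter, but it changes a different group, so it offers only weak guidance. Within the data shown here, compound 3 `CC(=O)Oc1ccc2c(c1)C(C)=CC(C)(C)N2Cc1ccccc1` carries acetyl in place of ethyl on an oxygen on an aromatic ring and no measured pair tests this swap. No step beyond the scatter is therefore expected in this assay and the estimated step is a 1.4-fold lower number from compound 1 to compound 3 (0.14 log units; within the scatter) for now. For compound 3 the expected value is 70000 nM (range 25000 nM to 160000 nM).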

Compound 3, half-maximal inhibitory concentration: 18000 nM
Compound 3: the middle estimate sits 3.9-fold (0.59 log units) above what was measured, and the stated range ends above it.
By their numbers in this assay, from the lowest: compound 3; then compounds 2 and 1 (each within the scatter of the next).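

In this assay, acetoxy in place of ethoxy gives a 5.4-fold lower number from compound 1 to compound 3 (0.73 log units; beyond the scatter) on the shared core, so this position on the aromatic ring can move the number beyond the scatter. The earlier change, on the phenyl group, did not do so. No measurement shown here explains the shift.

Still open, on these data alone, is how other acyl groups on this oxygen, such as propionyl or benzoyl, would read. As far as these compounds go, whether acetoxy brings a similar step when the 3,4-difluorophenyl group is present also remains unknown.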